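This account rests on a few compounds, and the source may have more. Where it says the series, first, only, none or still open, it means among the compounds named here.

Measured so far:
- compound 1 `Cc1ccc(CC(CNC(=O)C2(c3ccc(NS(C)(=O)=O)cc3)CC2)COC(=O)C(C)(C)C)cc1C`: 396 nM
- compound 2 `C[C@H](C(=O)NC[C@H](COC(=O)C(C)(C)C)Cc1ccccc1)c1ccc(NS(C)(=O)=O)c(F)c1`: 43 nM

In an assay on CHO cells for displacement of a labelled ligand from transient receptor potential cation channel subfamily V member 1 (Rattus norvegicus) (a lower number here means a stronger inhibitor, a higher number a weaker inhibitor), compound 2 gives 43 nM, the lower of the two numbers; compound 1 gives 396 nM, a gap beyond the scatter. Compound 3 `C[C@@H](C(=O)NC[C@@H](COC(=O)C(C)(C)C)Cc1ccccc1)c1ccc(NS(C)(=O)=O)c(F)c1` is not yet measured. How it differs from compound 2: the two compounds have the same atoms and bonds and differ only in configuration as drawn: 2 of 2 stereo elements differ (all stereocentres are inverted: mirror images); a stereocentre at a saturated chain carbon is drawn S in compound 2 and R in compound 3; a stereocentre at a saturated chain carbon is drawn R in compound 2 and S in compound 3. Going by the values given here, no step between mirror images is known, so the direction rests on the general behaviour of such pairs, where one enantiomer is usually weaker. A step towards a higher number, beyond the scatter, is expected: a 7.0-fold higher number from compound 2 to compound 3 (0.84 log units; beyond the scatter). Compound 3 is estimated at 300 nM, with a range from 60 nM to 1500 nM.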

Compound 3, inhibition constant: 370 nM
For compound 3 the middle estimate is 1.2-fold (0.09 log units) below the measured one; low and high end bracket the measured number.
By their numbers in this assay, from the lowest: compound 2; then compounds 3 and 1 (each within the scatter of the next).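

Inverting both stereocentres in this assay gives an 8.6-fold higher number from compound 2 to compound 3 (0.93 log units; beyond the scatter), the first step in this series that can be read within a single pair. The assay therefore separates these mirror images, and the step beyond the scatter can be assigned to configuration alone because nothing else distinguishes the pair: the fact that compounds 2 and 3 differ only in the configuration as drawn

As far as these compounds go, both stereocentres change together, so their separate contributions remain open. From the compounds shown here alone, it is also open whether the same preference holds with a carboxylic acid in place of the ester.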